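From fluoro to trifluoromethyl on a shared core

The compounds below may be only part of what the source reports. "The series", "measured", "known", "first", "only" and "open" are said of these compounds alone.

Compound 2 `COc1ccc(CNC(=O)c2c(C)[n+]([O-])c3ccc(F)cc3[n+]2[O-])cc1` was tested in an ADME assay on Vero cells (Chlorocebus sabaeus) for cytotoxicity, read by MTT assay, with a stated time of 72 h (on this read-out higher numbers stand for weaker inhibition and lower numbers for stronger inhibition), and gave > 30 ug/mL, which is a limit of the assay rather than a number. For compound 1 `COc1ccc(CNC(=O)c2c(C)[n+]([O-])c3ccc(OC)cc3[n+]2[O-])cc1` the entry in this assay reads "not determined" (no result reported). Compound 2 thus sits at the limit of > 30 ug/mL in this assay, at which 1 of the 2 values shown sits. Compound 3 `COc1ccc(CNC(=O)c2c(C)[n+]([O-])c3ccc(C(F)(F)F)cc3[n+]2[O-])cc1` differs from compound 2 by trifluoromethyl in place of fluoro on an aromatic carbon. Going by the values given here, no measured step covers such a change, so the step of a number no higher from compound 2 to compound 3 (the limit leaves the size open) is expected to be none beyond the scatter. Compound 3 is therefore estimated at 30 ug/mL, within a range from 12 ug/mL to 75 ug/mL, most likely again returned as a limit.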

Compound 3, half-maximal inhibitory concentration: > 30 ug/mL
Compound 3 ended at the assay's limit; the forecaster's own chance of this, stated with the estimate: 70%; the middle value lies on the limit itself.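

Going by these compounds alone, compound 2 and compound 3 both stand at a limit in this assay, so no step between them can be read: the limit of > 30 ug/mL in this assay, at which 2 of the 3 values shown sit.
On these data alone, how far the true values of these two compounds lie beyond that limit stays open.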